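The source may hold more compounds than are shown below. What is called first, only, known or untested is meant among the compounds shown, and "the series" means these compounds.

Compound 2 `CN1CCC(c2ccc(OCc3ccccc3)c(C(=O)Nc3ccnnc3)c2)CC1` stands lowest of the two compounds measured in a physicochemical assay for lipophilicity, at pH 7.4; on this read-out lower numbers stand for lower lipophilicity and higher numbers for higher lipophilicity: compound 2 gives 2.3, while compound 1 `O=C(Nc1cccc(Cl)c1)c1cc(C(F)(F)F)ccc1OCc1ccc(F)cc1` in this assay gives 8.7, a gap beyond the usual scatter. Compound 3 `O=C(Nc1ccnnc1)c1cc(N2CCCCC2)ccc1OCc1ccccc1` has not yet been measured in this assay. It differs from compound 2 in one place: piperidin-1-yl in place of 1-methylpiperidin-4-yl on an aromatic carbon, on an aromatic carbon of a six-membered aromatic ring of carbon only, meta to the (pyridazin-4-yl)carbamoyl group and para to the benzyloxy group. Among the measured compounds shown here, no measured pair shows this change, so the expectation rests on compound 2 alone. A step of a number 1.70 log units higher from compound 2 to compound 3 (beyond the scatter) upward is expected, beyond the scatter. For compound 3 the estimate in this assay is 4, ranging from 3 to 5.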

Compound 3, distribution coefficient: 6.3
Beside the measured number, compound 3's estimate is 2.30 log units below it, outside the stated range (above it).
By their numbers in this assay, from the lowest: compound 2; then compound 3; then compound 1.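

Among the compounds shown here, the change from 1-methylpiperidin-4-yl to piperidin-1-yl, para to the benzyloxy group, gives a step of a number 4.00 log units higher from compound 2 to compound 3 (beyond the scatter) in this assay, the first single-place comparison. This position is therefore highly sensitive in this read-out, although both groups are six-membered non-aromatic rings with 1 hetero atom and no net charge. Nothing measured here accounts for the size of this step. The compounds shown do not separate the point of ring attachment from the methyl group, as the two change together. Piperidin-4-yl, lacking the methyl, or a morpholine ring at this position remains open.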